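Replacing a cyclic sulfonamide with a hydroxy amide on the side chain

The compounds below may be only part of what the source reports. "The series", "measured", "known", "first", "only" and "open" are said of these compounds alone.

Measured compounds:
Compound 1 `NC[C@@H]1CCCc2cc(S(=O)(=O)c3cccc(O)c3)ccc21` gives 0.251 nM in an assay on isolated protein for displacement of a labelled ligand from 5-hydroxytryptamine receptor 6 (Homo sapiens); a lower number here means a stronger inhibitor, a higher number a weaker inhibitor.
Compound 2 `NC[C@@H]1CCCc2cc(S(=O)(=O)c3cn[nH]c3)ccc21` gives 2 nM in this assay.
Compound 3 `O=S(=O)(c1cccc(F)c1)c1ccc2c(c1)CCC[C@H]2CN1CCCS1(=O)=O` gives 31.6 nM in this assay.

Among the three measured compounds, compound 3 stands at the highest number in this assay, beyond the scatter from both compound 2 and compound 1. Compound 4 `CC(C)(O)C(=O)NC[C@@H]1CCCc2cc(S(=O)(=O)c3cccc(F)c3)ccc21` is not yet measured. It differs from compound 3 in one place: a group of 7 heavy atoms (4 carbon, 1 nitrogen, 2 oxygen; no ring) in place of a group of 7 heavy atoms (3 carbon, 1 nitrogen, 2 oxygen, 1 sulfur; one five-membered non-aromatic ring with 2 hetero atoms), on a saturated chain carbon bound to a saturated ring carbon.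

Among the measured compounds shown here, the only measured step, an 8.0-fold higher number from compound 1 to compound 2 (0.90 log units; beyond the scatter), changes the group on the sulfonyl sulfur and leaves the side chain untouched, so it does not bear on the change from compound 3 to compound 4. For the measured compounds named here, no measured pair varies the group on the saturated chain carbon while holding the rest fixed, so there is no direct precedent. Compound 3 and compound 4 share the 3-fluorophenyl on the sulfonyl sulfur and both carry a substituent on the chain nitrogen, which leaves the expectation open. Going by the values given here, with no guiding step, compound 4 is expected to land near compound 3, with a step of a 1.3-fold lower number from compound 3 to compound 4 (0.10 log units; within the scatter), and a wide range is allowed. The estimate for compound 4 is 25 nM, between 5 nM and 125 nM.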

Compound 4, inhibition constant: 2 nM
Compound 4: middle estimate off by 13-fold (1.10 log units), on the high side; measured number below the stated range.
By their numbers in this assay, from the lowest: compound 1; then compounds 2 and 4 (each within the scatter of the next); then compound 3.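

On the saturated chain carbon bound to a saturated ring carbon, the choice of group matters greatly in this assay: with the 3-fluorophenyl on the sulfonyl sulfur held fixed, putting ((1-hydroxy-1-methylethyl)carbonyl)amino in place of the cyclic sulfonamide gives a 16-fold lower number from compound 3 to compound 4 (1.20 log units; beyond the scatter). The two groups have the same heavy-atom count, yet they are not interchangeable here; the entering group has no ring and 2 hydrogen-bond donors, while the leaving group has a ring and 0. Nothing available explains the step or tells which of these differences carries it.

Going by these compounds, the step rests on this single pair, so it remains open whether it holds with 3-hydroxyphenyl or 1H-pyrazol-4-yl on the sulfonyl sulfur. Also open, on these data alone, is where the free amine, a plain acetamide or an open-chain methanesulfonamide would fall with the 3-fluorophenyl kept in place.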